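The source may hold more compounds than are shown below. What is called first, only, known or untested is meant among the compounds shown, and "the series" means these compounds.

Compound 1 `COC(=O)c1ccc(NCc2cncn2Cc2ccc(Br)cc2)cc1-c1ccccc1`: > 10000 nM
Compound 2 `c1ccc(-c2ccc(Cn3cncc3CNc3ccc(-c4ccccc4)c(-c4ccccc4)c3)cc2)cc1`: > 10000 nM

In a toxicity assay on NIH3T3 cells (Mus musculus) for cytotoxicity, read by resazurin assay (on this read-out higher numbers stand for an effect only at larger amounts of compound and lower numbers for an effect already at smaller amounts), compound 1 reaches only the limit of the assay, > 10000 nM. In this assay compound 2 likewise stops at the assay's limit, > 10000 nM. Both readings sit at the same point, (the limit of > 10000 nM in this assay, at which 2 of the 2 values shown sit), so no difference between the two can be seen. Compound 3 `CNC(=O)c1ccc(NCc2cncn2Cc2ccc(-c3ccccc3)cc2)cc1-c1ccccc1` differs from compound 2 by methylcarbamoyl in place of phenyl on an aromatic carbon. Among the compounds with values here, no measured step between compounds stands behind this change; with both known values at the limit, no shift beyond the scatter is expected. For compound 3 an estimated value of 15000 nM is expected, within 5000 nM to 50000 nM. The step this estimate means, a step that the limit leaves unreadable from compound 2 to compound 3, is expected to stay within the scatter.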

Compound 3, half-maximal effective concentration: > 1000 nM
Compound 3 was reported as a limit (the forecaster's own chance of this, stated with the estimate: 80%); the middle value does not contradict the limit.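

Within the data shown here, compound 2 and compound 3 both stop at a limit of the assay, so no step between them can be read. The compounds shown leave open at what concentration, if any, each one would reach its half-maximal effect in this assay.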